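The compounds below may be only part of what the source reports. "The series", "measured", "known", "first", "only" and "open" are said of these compounds alone.

Series notes. The shared core of compound 1 `Nc1ccccc1NC(=O)c1ccc(CSC(=S)N2CCN(Cc3ccccn3)CC2)cc1` is kept throughout; compound 2 `CC1CCCCN1C(=S)SCc1ccc(C(=O)Nc2ccccc2N)cc1` and compound 3 `CN(Cc1cccnc1)C(=S)SCc1ccc(C(=O)Nc2ccccc2N)cc1` carry other groups on the thiocarbonyl carbon. In a functional assay on HeLa cells (Homo sapiens) for antiproliferative activity, read by CCK-8 assay, with a stated time of 72 h, tested at 2 uM (a higher number here means a stronger effect of the compound at the concentration tested, a lower number a weaker effect), compound 1 gives 14.2%, the lowest of the three numbers; compound 3 gives 16.4%, within the scatter of compound 1, while compound 2 gives 45.5%, beyond it. Among the compounds with values here, the one measured step, a number 29.1 percentage points lower from compound 2 to compound 3 (beyond the scatter), comes from methyl((pyridin-3-yl)methyl)amino in place of 2-methylpiperidin-1-yl on a thiocarbonyl carbon.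

Compound 4 `Nc1ccccc1NC(=O)c1ccc(CSC(=S)N2CCN(c3ccc(F)cc3)CC2)cc1` differs from compound 1 by 4-fluorophenyl in place of (pyridin-2-yl)methyl on an amine nitrogen in a ring. Within the data shown here, no measured step touches the amine nitrogen in the ring, so the step from compound 2 to compound 3 bears on the present change only as a sign that this part of the molecule can move the read-out by a modest amount; the direction it suggests does not carry over. With compound 1 at 14.2% as the starting point, a step of a number 5.8 percentage points higher from compound 1 to compound 4 (within the scatter) is expected, most likely not beyond the scatter. Compound 4 is therefore estimated at 20%, within 6% to 42% in this assay.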

Compound 4, a percentage reported as inhibition, at one concentration (the size of the read-out at that concentration, not a potency): 60.8%
Compound 4: the middle estimate sits 40.8 percentage points below what was measured; the whole stated range lies below it.
By their numbers in this assay, from the lowest: compounds 1 and 3 (each within the scatter of the next); then compound 2; then compound 4.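

In this assay, the group on the amine nitrogen in the ring can carry a large change: 4-fluorophenyl in place of (pyridin-2-yl)methyl gives a number 46.6 percentage points higher from compound 1 to compound 4 (beyond the scatter). The earlier step showed sensitivity only to swapping the whole amine group on the thiocarbonyl carbon, whereas this one keeps the six-membered non-aromatic ring with 2 nitrogen and alters only what it bears. The two groups match in heavy-atom count but differ in three ways at once: the ring nitrogen, the fluorine and the methyl link. No measurement at hand accounts for this step. The compounds shown leave open which of these three differences goes with the higher number. Phenyl, 4-fluorobenzyl or pyridin-2-yl on the same nitrogen would separate them.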